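The source may report more compounds than this note shows. Statements on the series, on what has been measured and on what is new or still open speak of the compounds shown alone.

In a functional assay on LNCaP cells (Homo sapiens) for antiproliferative activity (on this read-out lower numbers stand for stronger inhibition and higher numbers for weaker inhibition), compound 1 `Cn1ncc(Cl)c1-c1cc(C(=O)N[C@@H]2CN[C@H](CCO)C[C@H]2c2ccc(F)c(F)c2)oc1Cl` gives 60 nM, and compound 3 `C=CC[C@@H]1C[C@@H](c2ccc(Cl)c(Cl)c2)[C@H](NC(=O)c2cc(-c3c(Cl)cnn3C)c(Cl)o2)CN1` gives 160 nM. Compound 2 `CC(=O)OCC[C@@H]1C[C@@H](c2ccc(F)c(F)c2)[C@H](NC(=O)c2cc(-c3c(Cl)cnn3C)c(Cl)o2)CN1` shares the same core, but in this assay compound 2 shows "not determined" (no result reported), so it has no reported value and cannot be placed on the numbers shown. Compound 4 `Cn1ncc(Cl)c1-c1cc(C(=O)N[C@@H]2CN[C@H](CC(O)CO)C[C@H]2c2ccc(F)c(F)c2)oc1Cl` is not yet measured. The change from compound 2 to compound 4 is 1,2-dihydroxyethyl in place of acetoxymethyl on a saturated chain carbon bound to a saturated ring carbon. With no number for compound 2, the size of this step cannot be computed. Compound 4 is closest in build to compound 1, and a result in the same region as compound 1 is expected, without a move beyond the scatter. Compound 4 is expected to give about 80 nM in this assay. For compound 4 the estimated range runs from 30 nM to 250 nM.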

Compound 4, half-maximal inhibitory concentration: 100 nM
Compound 4: the middle estimate sits 1.3-fold (0.10 log units) below what was measured; measured number inside the range.
By their numbers in this assay, from the lowest: compounds 1, 4 and 3 (each within the scatter of the next, the first and the last beyond it).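

In this assay, hydroxymethyl in place of hydrogen on a saturated chain carbon bound to an oxygen on a saturated carbon and a saturated chain carbon gives a 1.7-fold higher number from compound 1 to compound 4 (0.22 log units; within the scatter), so this pair shows that the chain can carry the extra hydroxymethyl without a shift beyond the scatter. No measured evidence accounts for this result. Any step from compound 2 cannot be read. From the compounds shown here alone, whether an amine, a carboxylic acid or a longer chain at this place would stay in the same region remains open.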